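Methyl for methoxy on the aryl ring of compound 3

This account rests on a few compounds, and the source may have more. Where it says the series, first, only, none or still open, it means among the compounds named here.

Measured so far:
compound 1 `CCCN(CCC)c1nc(C)nc2c(-c3c(C)cc(OC)cc3OC)c(C)nn12`: 3.72 nM
compound 2 `CCCCN(CC)c1nc(C)nc2c(-c3ccc(OC)cc3C)c(C)nn12`: 2.3 nM
compound 3 `CCCCN(CC)c1nc(C)nc2c(-c3c(C)cc(OC)cc3OC)c(C)nn12`: 1.72 nM

In an assay on cell membranes for displacement of a labelled ligand from corticotropin-releasing factor receptor 1 (Rattus norvegicus) (a higher number here means a weaker inhibitor, a lower number a stronger inhibitor), compound 3 gives 1.72 nM, the lowest of the three numbers. Compound 2 stands nearest to it with 2.3 nM, a gap within the scatter, so the two cannot be ranked. Compound 1 stands furthest with 3.72 nM, a gap beyond the scatter. The change of the amine, a 2.2-fold lower number from compound 1 to compound 3 (0.34 log units; beyond the scatter), is a modest step; the change on the aryl ring, a 1.3-fold lower number from compound 2 to compound 3 (0.13 log units; within the scatter), is within the scatter.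

Compound 4 `CCCCN(CC)c1nc(C)nc2c(-c3c(C)cc(OC)cc3C)c(C)nn12` differs from compound 3 by methyl in place of methoxy on an aromatic carbon. Going by the values given here, only one measured step bears on this position: there, hydrogen against methoxy on the same carbon left the number essentially unchanged (a 1.3-fold lower number from compound 2 to compound 3 (0.13 log units; within the scatter)). A swap of methoxy for methyl at that carbon is therefore expected to give no step beyond the scatter in this assay. Compound 4 is expected at 2 nM, with a range from 0.8 nM to 5 nM. This estimate corresponds to an expected 1.2-fold higher number from compound 3 to compound 4 (0.07 log units; within the scatter).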

Compound 4, half-maximal inhibitory concentration: 4.22 nM
Estimate against measurement, compound 4: 2.1-fold (0.32 log units) below, within the range that was stated.
By their numbers in this assay, from the lowest: compounds 3, 2, 1 and 4 (each within the scatter of the next, the first and the last beyond it).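

In this assay, methyl in place of methoxy on this aromatic carbon gives a 2.5-fold higher number from compound 3 to compound 4 (0.39 log units; beyond the scatter) and so shows that the position is not indifferent to its substituent, which the hydrogen and methoxy pair alone could not show. Hydrogen remains unresolved from methyl, with a 1.8-fold higher number from compound 2 to compound 4 (0.26 log units; within the scatter) as the step between them, so the only separation at this carbon is between the methoxy and methyl compounds. Nothing available here accounts for that separation.

Open, on these data alone, is whether ethoxy, chlorine, fluorine or hydroxy on this carbon would fall with methoxy, with methyl or outside both. Also open, as far as these compounds go, is whether the methoxy and methyl separation persists when dipropylamino, the amine of compound 1, replaces butyl(ethyl)amino on the shared core.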